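Adding a Methoxy Group to Compound 2

The compounds below may be only part of what the source reports. "The series", "measured", "known", "first", "only" and "open" are said of these compounds alone.

In a functional assay on UACC-62 cells (Homo sapiens) for inhibition, read by sulforhodamine B assay, with a stated time of 48 h (on this read-out lower numbers stand for stronger inhibition of growth and higher numbers for weaker inhibition of growth), compound 1 (`CC1(/C=C/c2ccccc2)C=CC(=O)O1`) gives 97200 nM and compound 2 (`COc1ccc(/C=C/C2(C)C=CC(=O)O2)c(OC)c1`) gives 80100 nM so that the two values lie within the scatter of each other. Compound 3 (`COc1ccc(/C=C/C2(C)C=CC(=O)O2)c(OC)c1OC`) has methoxy in place of hydrogen on an aromatic carbon, ortho to two methoxy groups, a change counted as methoxy in place of hydrogen on an aromatic carbon in all. Among the measured compounds shown here, no measured step covers this change. In this assay no step beyond the scatter is expected, with an estimated 1.1-fold lower number from compound 2 to compound 3 (0.03 log units; within the scatter) overall. Compound 3 is expected at 75000 nM with an estimated range of 35000 nM to 130000 nM around it.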

Compound 3, concentration for total growth inhibition: 71500 nM
Estimate against measurement, compound 3: 1.0-fold (0.02 log units) above; the measured number falls inside the stated range.
By their numbers in this assay, from the lowest: compounds 3, 2 and 1 (each within the scatter of the next).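

In this assay, methoxy in place of hydrogen on this aromatic carbon, ortho to two methoxy groups, gives a 1.1-fold lower number from compound 2 to compound 3 (0.05 log units; within the scatter), so the step stays within the scatter. Among the compounds shown here, the earlier compounds gave no reading of any change at this position, and this result is the first. Nothing given here offers an account of this result. Whether an amine, a carboxylic acid or a longer chain at this position would also stay within the scatter remains open, since the compounds shown hold only hydrogen or methoxy there.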